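This account rests on a few compounds, and the source may have more. Where it says the series, first, only, none or still open, it means among the compounds named here.

Series notes, efficacy read-out.

Of the compounds shown here, three of the shared core have a number so far. In a functional assay for antagonist activity at melanin-concentrating hormone receptor 1 (Homo sapiens), read by cAMP accumulation (on this read-out lower numbers stand for smaller maximal responses and higher numbers for larger maximal responses), compound 1 `CO[C@@H]1CN(CC2Cc3ccccc3C2)CC[C@H]1n1c(C)nc2cc(C)ccc21` gives 90%. In this assay compound 2 `CO[C@@H]1CN(C[C@H]2Cc3ccc(C#N)cc3C2)CC[C@H]1n1c(C(C)(C)O)nc2cc(C)ccc21` gives 85%, and compound 3 `CO[C@H]1CN(CCCc2cccc(NC(=O)C3CC3)c2)CC[C@@H]1n1c(C)nc2cc(C)ccc21` gives 82%. On the numbers shown, compound 1 stands with the larger value, but its gaps to compound 2 and to compound 3 both fall within the usual scatter of repeated measurements, so the three maximal responses are treated as indistinguishable; no ordering among them is claimed.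

The next compound, compound 4 `CO[C@@H]1CN(C[C@H]2Cc3ccc(Br)cc3C2)CC[C@H]1n1c(C)nc2cc(C)ccc21`, has not yet been measured in this assay. It is reached from compound 1 by a single change: bromo in place of hydrogen on an aromatic carbon. Among the compounds with values here, compound 2 carries a nitrile on the same six-membered aromatic ring of its fused system and gives a maximal response within the scatter of compound 1, which is the only comparison available for a substituent on that ring.

For compound 4 in this assay, the step of a number 4 percentage points lower from compound 1 to compound 4 (within the scatter) is expected to be none beyond the scatter. Compound 4 is therefore estimated at 86%, in a range from 74% to 98%.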

Compound 4, largest response reached (reported as efficacy), in percent of the reference or control that the assay uses: 92%
Beside the measured number, compound 4's estimate is 6 percentage points below it; the range from low to high includes it.
By their numbers in this assay, from the lowest: compounds 3, 2, 1 and 4 (each within the scatter of the next).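

In this assay the change from 2,3-dihydro-1H-inden-2-yl to 5-bromo-2,3-dihydro-1H-inden-2-yl is a number 2 percentage points higher from compound 1 to compound 4 (within the scatter) and so gives no step beyond the scatter. Within the data shown here, this pair is the first comparison in which a substituent on this six-membered aromatic ring is the only difference, since compound 2 carries its nitrile there but also differs from compound 1 in a second place. No measurement to hand explains this outcome.

On these data alone, whether the maximal response stays within the scatter with an amine or a carboxylic acid on this aromatic carbon remains open. Also open, as far as these compounds go, is whether bromo gives a comparable step when the core carries the other groups seen in compound 2.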